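This account rests on a few compounds, and the source may have more. Where it says the series, first, only, none or still open, it means among the compounds named here.

Of the compounds shown here, three have numbers so far in a functional assay on P388 cells (Mus musculus) for inhibition; on this read-out higher numbers stand for an effect only at larger amounts of compound and lower numbers for an effect already at smaller amounts. Compound 1 (`Nc1nc(N)c2ncn(C3CCC(CO)C3)c2n1`) gives 80 ug/mL, compound 2 (`Nc1nc(Cl)c2nnn(C3CCC(CO)C3)c2n1`) gives 18 ug/mL, and compound 3 (`Nc1nc(O)c2nnn(C3C=CC(CO)C3)c2n1`) gives 4.5 ug/mL. Compound 2 is therefore second highest of the three, with gaps beyond the scatter on either side. Compound 4 (`Nc1nc(O)c2nnn(C3CCC(CO)C3)c2n1`) is still unmeasured and departs from compound 2 in one place: hydroxy in place of chloro on an aromatic carbon. Within the data shown here, no measured pair shows this change alone. The only hint comes from a compound that also carries hydroxy but differs from compound 4 elsewhere: compound 3 gives 4.5 ug/mL. The expected change is a 1.8-fold lower number from compound 2 to compound 4 (0.26 log units; within the scatter), a small move toward a lower number that may stay within the scatter. For compound 4 the estimated value is 10 ug/mL, with an expected range of 3 ug/mL to 40 ug/mL.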

Compound 4, concentration for half-maximal effect: 51 ug/mL
Compound 4: middle estimate off by 5.1-fold (0.71 log units), on the low side, outside the stated range (above it).
By their numbers in this assay, from the lowest: compound 3; then compound 2; then compounds 4 and 1 (each within the scatter of the next).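

Among these compounds, this is the first step that changes only the group on this aromatic carbon: hydroxy in place of chloro gives a 2.8-fold higher number from compound 2 to compound 4 (0.45 log units; beyond the scatter). With the rest of the molecule held fixed, the number moves up, so hydroxy on this carbon does not by itself bring a low number. Compound 3 also carries hydroxy and has a double bond in the carbon ring that holds the hydroxymethyl group; it gives 4.5 ug/mL, while compound 4 gives 51 ug/mL.

No measurement on hand explains the rise. Going by these compounds, how a methoxy or bromo group on this same carbon would compare remains open.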